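The source may hold more compounds than are shown below. What is called first, only, known or untested is meant among the compounds shown, and "the series" means these compounds.

Of the compounds shown here, three of the same series have been measured so far. In a functional assay on CCRF-CEM cells for antagonist activity at C-X-C chemokine receptor type 4 (Homo sapiens), read by calcium flux, with stated times of 25 min and 90 s (a higher number here means a weaker inhibitor, a lower number a stronger inhibitor), compound 1 `CCCN(C[C@H]1Cc2c(cccc2N2CCNCC2)CN1)[C@H]1CCCc2cccnc21` gives 32.2 nM, compound 2 `CN(C[C@H]1Cc2c(cccc2N2CCN(C3CC3)CC2)CN1)[C@H]1CCCc2cccnc21` gives 23.5 nM, and compound 3 `Cc1cnc2c(c1)CCC[C@@H]2N(C)C[C@H]1Cc2c(cccc2N2CCNCC2)CN1` gives 16.1 nM. Compound 2 holds the second highest of the three numbers; its nearest neighbour is compound 1 and compound 3 lies furthest from it, yet both gaps sit within the usual scatter of this assay, so the three compounds cannot be told apart on these numbers. Among the measured compounds shown here, none of them differs from another in a single place, so no step between measured compounds is available.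

Compound 4 `CC(C)N1CCN(c2cccc3c2C[C@H](CN(C)[C@H]2CCCc4cccnc42)NC3)CC1` has not yet been measured. It differs from compound 2 in one place: isopropyl in place of cyclopropyl on an amine nitrogen in a ring. The group that leaves and the group that enters carry the same count of heavy atoms, with no donor or acceptor on either side; one holds a three-membered ring and the other holds none.

For the measured compounds named here, the three values so far lie close together, and no measured step tests this part of the molecule. The step of a 1.1-fold higher number from compound 2 to compound 4 (0.03 log units; within the scatter) is expected to be small, with no direction beyond the scatter. Compound 4 is therefore estimated at 25 nM in this assay, with a range from 10 nM to 65 nM.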

Compound 4, half-maximal inhibitory concentration: 16.9 nM
Beside the measured number, compound 4's estimate is 1.5-fold (0.17 log units) above it, within the range that was stated.
By their numbers in this assay, from the lowest: compounds 3, 4, 2 and 1 (each within the scatter of the next).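

Replacing cyclopropyl with isopropyl on this amine nitrogen, which turns 4-cyclopropylpiperazin-1-yl into 4-isopropylpiperazin-1-yl, gives a 1.4-fold lower number from compound 2 to compound 4 (0.14 log units; within the scatter) in this assay and leaves the two compounds indistinguishable. Among the compounds shown here, this is the first direct test of the position, since the earlier compounds each differed in more than one place and could not isolate it, and it shows that opening the three-membered ring while keeping the same count of heavy atoms produces no readable change in this assay. No separate measurement bears on this result, so it stands as an observation without an explanation.

For the compounds shown here, only this one pair isolates the nitrogen, so a longer chain such as n-butyl, a benzyl group or an acetyl group in this place remains open. Also open, on these data alone, is whether the same swap would give a similarly small step on the core of compound 3, and how a plain hydrogen on this nitrogen compares with cyclopropyl on the core of compound 2.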